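The source may report more compounds than this note shows. Statements on the series, on what has been measured and on what is new or still open speak of the compounds shown alone.

Measured compounds: compound 1 `COc1ccc(CNC(=O)c2nc(-c3ccc(F)cc3)n(CC[C@@H](O)C[C@@H](O)CC(=O)O)c2C2CC2)cc1F`, 3.7 nM in an assay on microsomes from liver for inhibition of 3-hydroxy-3-methylglutaryl-coenzyme A reductase (Rattus norvegicus), read by scintillation counting, with stated times of 0.5 h and 0.75 h; on this read-out higher numbers stand for weaker inhibition and lower numbers for stronger inhibition; compound 2 `Cc1cccc(CNC(=O)c2nc(-c3ccc(F)cc3)n(CC[C@@H](O)C[C@@H](O)CC(=O)O)c2C2CC2)c1`, 7.2 nM; compound 3 `CC(C)c1c(C(=O)NCc2ccccc2)nc(-c2ccc(F)cc2)n1CC[C@@H](O)C[C@@H](O)CC(=O)O`, 7.9 nM.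

Compound 3 and compound 2 lie within the scatter of each other, while the gap from compound 1 to compound 3 lies beyond it. For the measured compounds named here, the one measured step, a 1.9-fold higher number from compound 1 to compound 2 (0.29 log units; within the scatter), changes the benzyl group, not the group that is varied here, so it does not bear directly on the step to compound 4 `O=C(O)C[C@H](O)C[C@H](O)CCn1c(-c2ccc(F)cc2)nc(C(=O)NCc2ccccc2)c1C1CC1`. Compound 4 differs from compound 3 by cyclopropyl in place of isopropyl on an aromatic carbon. Compounds 1 and 2 both carry a cyclopropyl at that position, and their values bracket the value of compound 3 within the scatter or close to it. No direct pairing of isopropyl against cyclopropyl with an otherwise unchanged structure is available. The expectation is therefore a step of a 1.3-fold lower number from compound 3 to compound 4 (0.12 log units; within the scatter) that stays within the scatter. Compound 4 is estimated at 6 nM, with a range from 2.5 nM to 14 nM.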

Compound 4, half-maximal inhibitory concentration in the 3-hydroxy-3-methylglutaryl-coenzyme A reductase assay: 1.4 nM
Compound 4: middle estimate off by 4.3-fold (0.63 log units), on the high side; measured number below the stated range.
By their numbers in the 3-hydroxy-3-methylglutaryl-coenzyme A reductase assay, from the lowest: compound 4; then compounds 1, 2 and 3 (each within the scatter of the next, the first and the last beyond it).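

In the 3-hydroxy-3-methylglutaryl-coenzyme A reductase assay, the direct comparison at this position gives a 5.6-fold lower number from compound 3 to compound 4 (0.75 log units; beyond the scatter) for cyclopropyl in place of isopropyl on the aromatic carbon, so this exchange of two groups of equal heavy-atom count is not a neutral one. The cyclopropyl group does not set the number alone, since the benzyl group still counts: hydrogen in place of methyl gives a 5.1-fold lower number from compound 2 to compound 4 (0.71 log units; beyond the scatter), and phenyl in place of 3-fluoro-4-methoxyphenyl gives a 2.6-fold lower number from compound 1 to compound 4 (0.42 log units; beyond the scatter). In a physicochemical assay for lipophilicity, using the shake flask method, at pH 7.4 (a higher number here means a more lipophilic compound, a lower number a more polar compound), compound 3 gives 0.64 and compound 4 gives 0.03, so the gain in inhibition comes with a less lipophilic compound, not a more lipophilic one: the measured distribution coefficient of compound 3, 0.64, and of compound 4, 0.03, a number 0.61 log units lower (beyond the scatter)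

For the compounds shown here, only one pair isolates this change, so its size with a substituted benzyl group stays open. So does the outcome with a cyclobutyl or tert-butyl group on this aromatic carbon.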